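The source may report more compounds than this note shows. Statements on the series, on what has been measured and on what is new or still open speak of the compounds shown alone.

Measured compounds:
- Compound 1 `COc1cc2c(Oc3ccc(NC(=O)c4nn(-c5ccccc5)c(=O)cc4C)cc3F)ccnc2cc1OCCCN1CCCC1` — 120 nM
- Compound 2 `COc1cc2c(Oc3ccc(NC(=O)c4nn(-c5ccccc5)c(=O)cc4C)cc3F)ccnc2cc1OCCCN1CCN(C)CC1` — 130 nM

In a functional assay on MKN-45 cells (Homo sapiens) for inhibition, read by MTT assay, with a stated time of 72 h (on this read-out lower numbers stand for stronger inhibition and higher numbers for weaker inhibition), compound 1 gives 120 nM, the lowest of the two numbers shown, and in this assay compound 2 gives 130 nM. The step of a 1.1-fold higher number from compound 1 to compound 2 (0.03 log units; within the scatter) shows that swapping the amine at the end of the chain leaves the result essentially where it was.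

Compound 3 `COc1cc2c(Oc3ccc(NC(=O)c4nn(-c5ccc(F)c(F)c5)c(=O)cc4C)cc3F)ccnc2cc1OCCCN1CCCC1` differs from compound 1 in a different place: 3,4-difluorophenyl in place of phenyl on an aromatic nitrogen. Among the measured compounds shown here, the only step measured so far concerns the chain amine, not the ring on the aromatic nitrogen, so no measured step bears directly on this change; what remains is the observation that the one change tried so far moved the number little.

On that basis, the step of a 1.1-fold lower number from compound 1 to compound 3 (0.04 log units; within the scatter) is expected to stay small, in either direction, with no change beyond the scatter foreseen. Compound 3 is therefore estimated at 110 nM, within a range of 40 nM to 300 nM.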

Compound 3, half-maximal inhibitory concentration: 80 nM
Compound 3: middle estimate off by 1.4-fold (0.14 log units), on the high side; measured number inside the range.
By their numbers in this assay, from the lowest: compounds 3, 1 and 2 (each within the scatter of the next).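

Among the compounds shown here, this is the first measurement at the ring on the aromatic nitrogen, and in this assay putting 3,4-difluorophenyl in place of phenyl gives a 1.5-fold lower number from compound 1 to compound 3 (0.18 log units; within the scatter). The position therefore accepts a phenyl ring carrying two fluorine atoms, but this assay cannot tell compound 3 and compound 1 apart, just as it could not separate the two amines at the end of the chain. Nothing measured here reveals what the fluorine atoms do at this position.

Still open, going by these compounds, is whether a different group on the aromatic nitrogen, such as 4-methoxyphenyl, 4-trifluoromethylphenyl or a plain methyl, would move the number beyond the scatter. Also open, on these data alone, is whether 3,4-difluorophenyl would give a similar result when paired with the 4-methylpiperazin-1-yl chain end.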